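Exchanging a ring substituent on compound 1

The source may report more compounds than this note shows. Statements on the series, on what has been measured and on what is new or still open speak of the compounds shown alone.

Compound 1 `Nc1ccccc1NC(=O)c1ccc(CSC(=S)N2CCN(C3CCCCC3)CC2)cc1` and compound 2 `CCN(Cc1ccncc1)C(=S)SCc1ccc(C(=O)Nc2ccccc2N)cc1` share one core and differ on the amine side. In a functional assay on MGC-803 cells (Homo sapiens) for antiproliferative activity, read by CCK-8 assay, with a stated time of 72 h, tested at 2 uM (on this read-out lower numbers stand for a weaker effect and higher numbers for a stronger effect at the one concentration tested), compound 1 gives 16.9%, the lower of the two numbers; compound 2 gives 71.6%, higher by a margin beyond the scatter. Compound 3 `Nc1ccccc1NC(=O)c1ccc(CSC(=S)N2CCN(c3ccccc3F)CC2)cc1` keeps the framework of compound 1 with a single change: 2-fluorophenyl in place of cyclohexyl on an amine nitrogen in a ring. Among the measured compounds shown here, no measured pair isolates this change, so its size is unknown; compound 2 shows only that this part of the molecule can matter. Relative to compound 1, a modest rise is expected for compound 3, a number 13.1 percentage points higher from compound 1 to compound 3 (beyond the scatter), possibly not beyond the scatter. Compound 3 is estimated at 30% in this assay, range 10% to 60%.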

Compound 3, a percentage reported as inhibition, at one concentration (the size of the read-out at that concentration, not a potency): 33.7%
Compound 3: middle estimate off by 3.7 percentage points, on the low side; low and high end bracket the measured number.
By their numbers in this assay, from the lowest: compound 1; then compound 3; then compound 2.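

In this assay, the substituent on the amine nitrogen in a ring now has a single-change step: 2-fluorophenyl in place of cyclohexyl gives a number 16.8 percentage points higher from compound 1 to compound 3 (beyond the scatter) and so is a modest gain. The position therefore responds to this exchange alone, with the rest of the core of compound 1 held fixed. Nothing measured here accounts for the step.

From the compounds shown here alone, the change swaps the ring type and adds fluorine at once, so the share of each stays open. Unsubstituted phenyl or a methyl group on the same nitrogen would separate these parts.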